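Lengthening the chain that carries the acetyl group

The source may report more compounds than this note shows. Statements on the series, on what has been measured and on what is new or still open speak of the compounds shown alone.

In a functional assay (trachea) with Cavia porcellus as the target (on this read-out higher numbers stand for an effect only at larger amounts of compound and lower numbers for an effect already at smaller amounts), compound 1 (`CCCn1c(=O)n(CCCOC)c(=O)c2[nH]cnc21`) gives 2900 nM and compound 2 (`CCCn1c(=O)n(CC(C)=O)c(=O)c2[nH]cnc21`) gives 14900 nM as the higher of the two numbers. Compound 3 (`CCCn1c(=O)n(CCCCC(C)=O)c(=O)c2[nH]cnc21`) keeps the shared core and differs from compound 2 by 3-acetylpropyl in place of acetyl on a saturated chain carbon bound to an aromatic nitrogen with 3-acetylpropyl in place of acetyl on a saturated chain carbon bound to an aromatic nitrogen. Going by the values given here, only one measured step bears on this change: a 5.1-fold higher number from compound 1 to compound 2 (0.71 log units; beyond the scatter) at that same place, a modest step beyond the scatter. One step is thin evidence, but a move of similar size back to a lower number seems likely. The expected change in this assay is a 4.3-fold lower number from compound 2 to compound 3 (0.63 log units; beyond the scatter) as estimated here. Compound 3 is estimated at 3500 nM with an expected range from 900 nM to 12000 nM in a repeat measurement.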

Compound 3, half-maximal effective concentration: 60 nM
Compound 3: the middle estimate sits 58-fold (1.77 log units) above what was measured; the measured number lies below the stated range.
By their numbers in this assay, from the lowest: compound 3; then compound 1; then compound 2.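

In this assay, going by these compounds alone, the length of the chain carrying the acetyl group matters far more at this position than the earlier compounds showed: 3-acetylpropyl in place of acetyl brings a 250-fold lower number from compound 2 to compound 3 (2.40 log units; beyond the scatter). The longer acetyl-bearing chain also separates clearly from the methoxy-ended chain, with a 48-fold lower number from compound 1 to compound 3 (1.68 log units; beyond the scatter). Nothing measured here accounts for a step of this size.

The compounds shown leave open whether a still longer chain would lower the number further, and how chains of intermediate length behave. They also leave open whether an amine or a carboxylic acid could stand in place of the acetyl group.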